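Trimming the Aryl Group from an Amidine Naphthoquinone

A few compounds are considered here, and "the series" means these few. Any claim that something is new, unique, unknown or untested is made for them only; others in the source may bear on it.

Compound 1 `Cc1ccc(S(=O)(=O)/N=C(/CCNC2=CC(=O)c3ccccc3C2=O)Nc2ccccc2[N+](=O)[O-])cc1`: 3310 nM
Compound 2 `COc1ccc(N/C(CCNC2=CC(=O)c3ccccc3C2=O)=N\S(=O)(=O)c2ccc(C)cc2)cc1OC`: 14500 nM

Both compounds share one core and were tested in a functional assay on HeLa cells (Homo sapiens) for cytotoxicity, read by MTT assay, with a stated time of 48 h; a higher number here means a weaker inhibitor, a lower number a stronger inhibitor. Compound 1 gives the lowest of the two numbers and compound 2 a higher one, with a 4.4-fold higher number from compound 1 to compound 2 (0.64 log units; beyond the scatter). Compound 3 `Cc1ccc(S(=O)(=O)/N=C(\N)CCNC2=CC(=O)c3ccccc3C2=O)cc1` has not yet been tested; it differs from compound 1 by hydrogen in place of 2-nitrophenyl on an amine nitrogen. Among the compounds with values here, only the step from compound 1 to compound 2 bears on this, since it also swaps the group on that amine nitrogen, and it brought a modest rise. A rise of similar size is therefore expected, a 2.4-fold higher number from compound 1 to compound 3 (0.38 log units; beyond the scatter). Compound 3 is estimated at 8000 nM, between 2500 nM and 25000 nM.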

Compound 3, half-maximal inhibitory concentration: 24600 nM
The estimate for compound 3 lay 3.1-fold (0.49 log units) below the measured number; the measured number falls inside the stated range.
By their numbers in this assay, from the lowest: compound 1; then compounds 2 and 3 (each within the scatter of the next).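

Hydrogen in place of 2-nitrophenyl on the amine nitrogen gives a 7.4-fold higher number from compound 1 to compound 3 (0.87 log units; beyond the scatter) in this assay and shows that the aryl group of compound 1 is worth keeping in this assay. With a 1.7-fold higher number from compound 2 to compound 3 (0.23 log units; within the scatter) as the other step, 3,4-dimethoxyphenyl and bare hydrogen cannot be told apart at this position, so among these groups only 2-nitrophenyl stands out. Nothing at hand explains this.

On these data alone, whether the nitro group or the phenyl ring carries the difference stays open. A plain phenyl or a methyl group on this nitrogen would help to separate the two.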